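Benzoyl removal on the side-chain oxygen of compound 1

The source may report more compounds than this note shows. Statements on the series, on what has been measured and on what is new or still open speak of the compounds shown alone.

Measured so far:
- compound 1, `COC(=O)/C(=C/Cn1c(-c2ccccc2)ncc(NC(=O)OCc2ccccc2)c1=O)COC(=O)c1ccccc1`: 2.6 ug/mL
- compound 2, `COC(=O)/C(=C/[C@H](C)NC(=O)Cn1c(-c2ccccc2)ncc(NC(=O)OCc2ccccc2)c1=O)COC(C)=O`: 1.1 ug/mL
- compound 3, `COC(=O)/C(=C/Cn1c(-c2ccccc2)ncc(NC(=O)N2CCN(C(C)=O)CC2)c1=O)COC(C)=O`: 13.8 ug/mL

In a functional assay on cells (Neuronal cell line, Homo sapiens) for inhibition (on this read-out lower numbers stand for stronger inhibition and higher numbers for weaker inhibition), compound 1 gives 2.6 ug/mL and stands second highest of the three numbers. Compound 2 gives 1.1 ug/mL, a lower number than compound 1 by a gap beyond the scatter, and compound 3 gives 13.8 ug/mL, the highest number of the set and again beyond the scatter from compound 1. Within the data shown here, no pair among the measured compounds differs in one place only, so no single-point step is available for calibration.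

Compound 4, `COC(=O)/C(=C/Cn1c(-c2ccccc2)ncc(NC(=O)OCc2ccccc2)c1=O)CO`, is the next compound for this assay . It differs from compound 1 by hydrogen in place of benzoyl on an oxygen on a saturated carbon; the same difference, cut one bond further out, reads benzoyloxy to hydroxy, or (benzoyloxy)methyl to hydroxymethyl. The rest of the shared core is unchanged.

Among the measured compounds shown here, with no comparable step on record, the expectation rests on the spread of the three measured values alone. The step from compound 1 to compound 4 is expected to be modest and toward a higher number, a 1.9-fold higher number from compound 1 to compound 4 (0.28 log units; within the scatter), and may well fall within the scatter. Compound 4 is therefore estimated at 5 ug/mL in this assay , with a range from 1.5 ug/mL to 16 ug/mL.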

Compound 4, half-maximal inhibitory concentration: 0.95 ug/mL
Beside the measured number, compound 4's estimate is 5.3-fold (0.72 log units) above it, outside the stated range (below it).
By their numbers in this assay, from the lowest: compounds 4 and 2 (each within the scatter of the next); then compound 1; then compound 3.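

In this assay, the oxygen on a saturated carbon gives the series its first single-point step: hydrogen in place of benzoyl produces a 2.7-fold lower number from compound 1 to compound 4 (0.44 log units; beyond the scatter). The benzoyl group, with its six-membered aromatic ring of carbon only, is therefore not required for inhibition on the core of compound 1, and at this position the change from (benzoyloxy)methyl to hydroxymethyl goes with stronger inhibition, although the step is modest. No measurement shown bears on what lies behind this step.

The compounds shown do not settle whether the free hydroxy itself matters or whether removing the benzoyl group is enough, which a methyl ether or an amine on the same carbon would help to separate. On these data alone, it also remains open whether the same change carries over to the cores of compound 2 and compound 3, where this oxygen bears an acetyl group, and whether a longer acyl chain on the oxygen would be tolerated on the core of compound 1.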